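The source may hold more compounds than are shown below. What is called first, only, known or untested is meant among the compounds shown, and "the series" means these compounds.

Within the data shown here, in an assay on cells for inhibition of HSP60/HSP10 (Homo sapiens), with a stated time of 60 min (a higher number here means a weaker inhibitor, a lower number a stronger inhibitor), the compounds measured so far stand as follows.
Compound 1, `Cc1ccc(S(=O)(=O)Nc2ccc3oc(-c4ccccc4)nc3c2)cc1`, gives > 100000 nM, which is a limit of the assay rather than a number.
Compound 2, `O=S(=O)(Nc1ccc2oc(-c3ccccc3)nc2c1)c1ccc(Cl)cc1`, gives > 100000 nM, again a limit of the assay.
Compound 3, `CCc1ccc(S(=O)(=O)Nc2ccc3oc(-c4ccccc4)nc3c2)cc1`, gives > 100000 nM, likewise a limit of the assay.

Compound 3 therefore stands at the same limit as the other two; no order among the three can be read, since all of them sit at the limit of > 100000 nM in this assay, at which 3 of the 3 values shown sit. The three measured steps, a step that the two limits leave unreadable from compound 1 to compound 2, a step that the two limits leave unreadable from compound 1 to compound 3 and a step that the two limits leave unreadable from compound 2 to compound 3, all change the same aromatic carbon and all remain unreadable in size.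

Compound 4, `O=S(=O)(Nc1ccc2oc(-c3ccccc3)nc2c1)c1ccc(C(F)(F)F)cc1`, is the next change at that position: trifluoromethyl in place of ethyl on an aromatic carbon. All three measured steps bear on it, yet none of them yields a readable size, so the data give no direction for this assay. Compound 4 is therefore expected to give 150000 nM, within 50000 nM to 500000 nM, most likely again as a limit. The expected step is a step that the limit leaves unreadable from compound 3 to compound 4, none beyond the scatter.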

Compound 4, half-maximal inhibitory concentration: > 100000 nM
Compound 4: a limit, no number (the forecaster's own chance of this, stated with the estimate: 85%); the middle value lies beyond the limit too.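

In this assay compound 4 gives > 100000 nM as a limit of the assay. Among these compounds, no step from compound 1, compound 2 or compound 3 to compound 4 can be read: (the limit of > 100000 nM in this assay, at which 4 of the 4 values shown sit). As far as these compounds go, whether any other group at this aromatic carbon gives a readable value in this assay stays open.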